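Swapping trifluoromethyl for a larger fluorinated group

The source may hold more compounds than are shown below. What is called first, only, known or untested is meant among the compounds shown, and "the series" means these compounds.

Compound 1 `COCc1nc2nc(C)cc(Nc3ccc(S(F)(F)(F)(F)F)cc3)n2n1`: 63000 nM
Compound 2 `Cc1cc(Nc2ccc(S(F)(F)(F)(F)F)cc2)n2nc(C(C)(F)F)nc2n1`: 30000 nM
Compound 3 `CSc1nc2nc(C)cc(Nc3ccc(C(F)(F)F)cc3)n2n1`: 19000 nM

In a physicochemical assay for solubility, at pH 6.5 (on this read-out lower numbers stand for lower solubility and higher numbers for higher solubility), compound 3 gives the lowest of the three numbers. Its nearest neighbour is compound 2, which lies within the scatter of it, while compound 1 stands clearly higher, beyond the scatter.

Compound 4 `CSc1nc2nc(C)cc(Nc3ccc(S(F)(F)(F)(F)F)cc3)n2n1` is not yet measured. It differs from compound 3 in one place: a group of 6 heavy atoms (5 fluorine, 1 sulfur; no ring) in place of a group of 4 heavy atoms (1 carbon, 3 fluorine; no ring), on an aromatic carbon. The new group sits on an aromatic carbon of a six-membered aromatic ring of carbon only.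

Among the measured compounds shown here, none of the measured steps covers this particular change. For the measured compounds named here, the only single-place step measured is a 2.1-fold lower number from compound 1 to compound 2 (0.32 log units; beyond the scatter), and it concerns a different position on the shared core. Compound 1 and compound 2 both carry the incoming group of 6 heavy atoms, and both give higher numbers than compound 3, but each also differs from compound 3 elsewhere, so their values cannot be laid on this change alone.

Going by the values given here, with no step that bears on it, the expectation for compound 4 is a small move downward, if any, estimated as a 1.3-fold lower number from compound 3 to compound 4 (0.10 log units; within the scatter). Compound 4 is therefore estimated at 15000 nM, with a range from 7000 nM to 32000 nM.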

Compound 4, solubility: 7800 nM
Beside the measured number, compound 4's estimate is 1.9-fold (0.28 log units) above it; the measured number falls inside the stated range.
By their numbers in this assay, from the lowest: compound 4; then compounds 3 and 2 (each within the scatter of the next); then compound 1.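

With the shared core and the methylsulfanyl group held fixed, placing the group of 6 heavy atoms (5 fluorine, 1 sulfur) in the position of trifluoromethyl, on the six-membered aromatic ring of carbon only, gives in this assay a 2.4-fold lower number from compound 3 to compound 4 (0.39 log units; beyond the scatter), the only step shown for this change, and one that lies beyond the scatter. With that larger group held in place, the other changing position can now be read for methylsulfanyl as well, through a 3.8-fold lower number from compound 2 to compound 4 (0.59 log units; beyond the scatter) and an 8.1-fold lower number from compound 1 to compound 4 (0.91 log units; beyond the scatter), so among the three groups seen there, methylsulfanyl goes with the lowest number, and compound 4 stands lowest of all four compounds. No measurement shown here accounts for any of these steps.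

Whether the step from trifluoromethyl to the larger group would repeat with 1,1-difluoroethyl or methoxymethyl on the shared core stays open, as the compounds shown hold just one pair for this change. As far as these compounds go, how an amine or a carboxylic acid in either position would read in this assay also stays open.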